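This account rests on a few compounds, and the source may have more. Where it says the series, first, only, none or still open, it means among the compounds named here.

The series shares one core, carrying different aryl groups on the exocyclic double bond. Compound 1 `CCOC(=O)C1=C(Nc2ccccc2)S/C(=C\c2ccc(OC)cc2)C1=O` was tested in a functional assay on A549 cells (Homo sapiens) for inhibition, read by MTT assay, with a stated time of 72 h, tested at 10 uM (a lower number here means less inhibition, a higher number more inhibition at the concentration tested (going by the name of the read-out)), where compound 1 gives 17.5%. Compound 3 `CCOC(=O)C1=C(Nc2ccccc2)S/C(=C\c2cc(OC)c(O)c(OC)c2)C1=O` gives 19.2% in this assay, a value within the usual scatter of that of compound 1, so the two compounds cannot be told apart on these numbers. Compound 2 `CCOC(=O)C1=C(Nc2ccccc2)S/C(=C\c2ccccc2C(F)(F)F)C1=O` gives < 10% in this assay, and this is a limit of the assay rather than a number, as noted in the limit of < 10% in this assay, at which 1 of the 3 values shown sits. Among the compounds with values here, compound 1 thus stands with one of the two numbers actually read, and no compound in the set reaches a large effect.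

Compound 4 `CCOC(=O)C1=C(Nc2ccccc2)S/C(=C\c2ccc[nH]2)C1=O` has not yet been measured in this assay. It differs from compound 1 in one place: 1H-pyrrol-2-yl in place of 4-methoxyphenyl on a double-bonded chain carbon bound to a double-bonded ring carbon. Within the data shown here, no step of this kind is available among the measured compounds. The step expected from it, a number 2.5 percentage points lower from compound 1 to compound 4 (within the scatter), is estimated to be small and in no clear direction, within the scatter. Compound 4 is expected to give about 15% in this assay, with a range from 5% to 30%.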

Compound 4, a percentage reported as inhibition, at one concentration (the size of the read-out at that concentration, not a potency): 23.5%
Compound 4: the middle estimate sits 8.5 percentage points below what was measured, and the stated range covers the measured number.
By their numbers in this assay, from the lowest: compounds 1, 3 and 4 (each within the scatter of the next). At a limit, below all of these: compound 2.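

In this assay, the place on a double-bonded chain carbon bound to a double-bonded ring carbon now has its first single-change comparison, with a number 6 percentage points higher from compound 1 to compound 4 (within the scatter). This shows that the 4-methoxyphenyl group can give way to the smaller, five-membered 1H-pyrrol-2-yl ring, which swaps a hydrogen-bond acceptor for a hydrogen-bond donor, with no change that can be told from the scatter. The compounds shown offer no reason for this small step, and a single step sets no trend for this place.

As far as these compounds go, it remains open whether a furan ring or an aryl group bearing an amine or a carboxylic acid at this place would move the read-out beyond the scatter. From the compounds shown here alone, it is also open whether replacing the ethyl ester of the shared core with an amide would do so.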